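The source may report more compounds than this note shows. Statements on the series, on what has been measured and on what is new or still open speak of the compounds shown alone.

Working notes on the series. Compound 1 `COc1ccc(-c2cc(=O)c3c(OC)cc(OC)cc3[nH]2)cc1` is the parent of compound 2 `COc1ccc(-c2cc(=O)c3c(OC)cc(OC)cc3n2S(=O)(=O)c2ccc([N+](=O)[O-])cc2)cc1` and of the not yet measured compound 3 `COc1ccc(-c2cc(=O)c3c(OC)cc(OC)cc3n2S(=O)(=O)c2ccc(F)cc2)cc1`. In a functional assay on KOPN-8 cells (Homo sapiens) for antiproliferative activity, with a stated time of 72 h (on this read-out lower numbers stand for an effect already at smaller amounts and higher numbers for an effect only at larger amounts of compound), compound 1 gives only a limit, > 31100 nM, and no number. In this assay, among the measured compounds shown here, compound 2 gives 17300 nM, which is the only number among the values so far; the one other value sits at the limit of > 31100 nM in this assay, at which 1 of the 2 values shown sits. No step between two measured compounds is therefore available, and no cause can be attached to anything yet.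

Compound 3 differs from compound 2 by fluoro in place of nitro on an aromatic carbon, in words fluoro in place of nitro on an aromatic carbon. For the measured compounds named here, with no measured step to lean on, the expectation is a step of no clear direction and no size beyond the scatter, with a real chance that only a limit is reported. Compound 3 is accordingly estimated at 20000 nM, between 8000 nM and 60000 nM. That estimate means an expected step of a 1.2-fold higher number from compound 2 to compound 3 (0.06 log units; within the scatter).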

Compound 3, half-maximal effective concentration: > 65500 nM
Compound 3: a limit, no number (the forecaster's own chance of this, stated with the estimate: 40%); middle value at least 3.2-fold (0.51 log units) from the limit.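

In this assay, the series now has its first readable step, for fluoro in place of nitro on an aromatic carbon para to a large group: an at least 3.7-fold higher number from compound 2 to compound 3 (0.57 log units; beyond the scatter). This position is therefore not indifferent to what it carries, and among the sulfonyl compounds shown, the only number belongs to the 4-nitrophenyl group, not the 4-fluorophenyl group. The value of compound 3 is a limit and not a number, and the step from compound 1, also a limit, cannot be read: the limit of > 65500 nM in this assay, at which 1 of the 3 values shown sits.

On these data alone, how far compound 3 lies past its limit remains open, so the step gives only a lower bound on the size of the change. Also open, as far as these compounds go, is whether nitro itself matters or whether an amine, a nitrile or a carboxylic acid at the same place would give a number like that of compound 2.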